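Two methylphenyl groups on the ring amine nitrogen

A few compounds are considered here, and "the series" means these few. Any claim that something is new, unique, unknown or untested is made for them only; others in the source may bear on it.

Compound 1 `CCCn1c(=O)[nH]c2nc(-c3ccc(S(=O)(=O)N4CCN(c5ccccc5C)CC4)cc3)[nH]c2c1=O` gives 419 nM in an assay on CHO cells for displacement of a labelled ligand from adenosine receptor A1 (Homo sapiens), read by scintillation counting, with a stated time of 90 min, in the presence of a further agent that is not named here; a higher number here means a weaker inhibitor, a lower number a stronger inhibitor.
Compound 2 `CCCn1c(=O)[nH]c2nc(-c3ccc(S(=O)(=O)N4CCN(c5ccccc5Br)CC4)cc3)[nH]c2c1=O` reaches only a limit of the assay in this assay, > 1000 nM.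
Compound 3 `CCCn1c(=O)[nH]c2nc(-c3ccc(S(=O)(=O)N4CCN(c5ccccc5F)CC4)cc3)[nH]c2c1=O` likewise reaches only a limit in this assay, > 1000 nM.
Compound 4 `CCCn1c(=O)[nH]c2nc(-c3ccc(S(=O)(=O)N4CCN(c5ccc(C)cc5)CC4)cc3)[nH]c2c1=O` has not yet been measured in this assay.

Among the three measured compounds, compound 1 is the only one with an actual number in this assay; the other two sit at a limit, as stated in the limit of > 1000 nM in this assay, at which 2 of the 3 values shown sit. The step to compound 4 is 4-methylphenyl in place of 2-methylphenyl on an amine nitrogen in a ring. The measured steps all replace the methyl on the aromatic carbon by a halogen: an at least 2.3-fold higher number from compound 1 to compound 2 (0.37 log units; beyond the scatter) and an at least 2.3-fold higher number from compound 1 to compound 3 (0.37 log units; beyond the scatter), each reaching the limit, while the step between the two halogens is a step that the two limits leave unreadable from compound 2 to compound 3. None of them keeps the methyl and changes only which methylphenyl sits on the ring nitrogen, so they give no direct reading on the step to compound 4. With the methyl retained, the account expects compound 4 to stay close to compound 1, with a step of a 1.2-fold higher number from compound 1 to compound 4 (0.08 log units; within the scatter) that is not read as beyond the scatter. Compound 4 is therefore estimated at 500 nM, within a range from 200 nM to 1500 nM.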

Compound 4, inhibition constant: > 1000 nM
Compound 4 gave a limit, no number (the forecaster's own chance of this, stated with the estimate: 30%); middle value at least 2.0-fold (0.30 log units) from the limit.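

Keeping the methyl did not keep the value: with 4-methylphenyl in place of 2-methylphenyl on the amine nitrogen in the ring, this assay shows an at least 2.3-fold higher number from compound 1 to compound 4 (0.37 log units; beyond the scatter). The earlier steps changed the methyl itself, whereas this one shows that among these compounds the methyl gives a number only as 2-methylphenyl, in compound 1, and the steps from compound 2 and from compound 3 to compound 4 cannot be read, with limits at both ends. The value of compound 4 is a limit of the assay and not a number, and it places compound 4 with compound 2 and compound 3: the limit of > 1000 nM in this assay, at which 3 of the 4 values shown sit.

As far as these compounds go, how far compound 2, compound 3 and compound 4 lie from one another remains open, and so does the true size of the step to compound 4. Also open, from the compounds shown here alone, is whether a plain phenyl, or an ethyl or methoxy group in the place of the methyl of 2-methylphenyl, would give a number in this assay.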